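Chloro for Hydrogen on the Shared Core

The source may hold more compounds than are shown below. What is called first, only, known or untested is meant among the compounds shown, and "the series" means these compounds.

Compound 1 `ClCc1ccccc1Cn1cnc2c(Cl)nc(Cl)nc21`, compound 2 `ClCc1ccccc1Cn1cnc2c(Cl)ncnc21` and compound 3 `ClCc1cccc(Cn2cnc3ncnc(Cl)c32)c1` have been run in a functional assay on UACC-62 cells (Homo sapiens) for cytotoxicity, read by sulforhodamine B assay, with a stated time of 48 h; a lower number here means a stronger inhibitor of growth, a higher number a weaker inhibitor of growth. Compound 1 gives 2630 nM in this assay, compound 2 gives 6600 nM and compound 3 gives 5370 nM. Compound 2 and compound 3 hold the same atoms joined differently; the difference between their cores is not broken down here, and their two numbers lie within the scatter of one another. Compound 1 differs from compound 2 by chloro in place of hydrogen on an aromatic carbon, and this gave a 2.5-fold lower number from compound 2 to compound 1 (0.40 log units; beyond the scatter). Compound 4 `ClCc1cccc(Cn2cnc3nc(Cl)nc(Cl)c32)c1` has not yet been measured; it differs from compound 3 by chloro in place of hydrogen on an aromatic carbon, which is the same change in the same place. Among the compounds with values here, the step from compound 3 to compound 4 in this assay is expected to be a 2.3-fold lower number from compound 3 to compound 4 (0.37 log units; beyond the scatter), resting on the one earlier step of this kind, a 2.5-fold lower number from compound 2 to compound 1 (0.40 log units; beyond the scatter), and on compound 3 standing near compound 2. In this assay compound 4 is therefore estimated at 2300 nM, with a likely range from 1200 nM to 4500 nM.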

Compound 4, concentration for total growth inhibition: 2180 nM
For compound 4 the middle estimate is 1.1-fold (0.02 log units) above the measured one, and the stated range covers the measured number.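

Chloro in place of hydrogen on an aromatic carbon, at the place between two ring nitrogen atoms, gives in this assay a 2.5-fold lower number from compound 3 to compound 4 (0.39 log units; beyond the scatter). Set beside the earlier step, the change carries from one core to the other with its size unchanged: the same change on two cores in this assay, a 2.5-fold lower number (0.40 log units; beyond the scatter) from compound 2 to compound 1 and a 2.5-fold lower number (0.39 log units; beyond the scatter) from compound 3 to compound 4, 1.0-fold (0.01 log units) apart, within the scatter of two such steps. This shows agreement across two matched pairs in a single cell assay, and it does not show that the step would hold on a further core or in another assay, nor does it explain why the number moves.

The compounds shown hold only hydrogen or chloro at this place, so the outcome with an amine, a methoxy group or a thioether there remains open. On these data alone, the chloromethyl group is common to all four compounds, so it also remains open whether the step would persist with a hydroxymethyl group or a plain methyl group in its place.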